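Amide to methylpiperazine on the side chain

The compounds below may be only part of what the source reports. "The series", "measured", "known", "first", "only" and "open" are said of these compounds alone.

Of the compounds shown here, three sharing one core have been measured in an ADME assay on the whole organism (Mus musculus, strain C57BL/6) for pharmacokinetics, read by LC-MS, at a dose of 2 mg/kg by the subcutaneous route; a higher number here means more compound in the circulation at the dose given, a lower number less compound in the circulation. Compound 1 `Cc1ccccc1C(=O)Nc1ccc(C(=O)N2CCCC(NCCCc3ccncc3)c3cc(Cl)ccc32)c(C)c1` gives 565 ng.h/mL. Compound 2 `Cc1ccccc1C(=O)Nc1ccc(C(=O)N2CCCC(NCCCN3CCCCC3)c3cc(Cl)ccc32)c(C)c1` gives 1110 ng.h/mL. Compound 3 `Cc1ccccc1C(=O)Nc1ccc(C(=O)N2CCCC(NCCC(=O)N3CCOCC3)c3cc(Cl)ccc32)c(C)c1` gives 450 ng.h/mL. Compound 3 sits close to compound 1, the step of a 1.3-fold lower number from compound 1 to compound 3 (0.10 log units; within the scatter) lying within the scatter, while the step of a 2.5-fold lower number from compound 2 to compound 3 (0.39 log units; beyond the scatter) is a modest one beyond it. The step of a 2.0-fold higher number from compound 1 to compound 2 (0.29 log units; within the scatter) stays within the scatter.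

Compound 4 `Cc1ccccc1C(=O)Nc1ccc(C(=O)N2CCCC(NCCCN3CCN(C)CC3)c3cc(Cl)ccc32)c(C)c1` differs from compound 3 in one place: (4-methylpiperazin-1-yl)methyl in place of (morpholin-4-yl)carbonyl on a saturated chain carbon, two bonds along the chain from an amine nitrogen. The step that bears on this most directly is a 2.5-fold lower number from compound 2 to compound 3 (0.39 log units; beyond the scatter), where a (piperidin-1-yl)methyl group at the same place gave a modestly higher number than the (morpholin-4-yl)carbonyl group; compound 4 carries a ring of similar make-up to that of compound 2, joined through a saturated carbon rather than a carbonyl. A recovery toward the number of compound 2 is therefore expected, roughly as a 1.8-fold higher number from compound 3 to compound 4 (0.25 log units; within the scatter), though the change from compound 2 to compound 4 is not itself measured. Compound 4 is estimated at 800 ng.h/mL, with a range from 350 ng.h/mL to 1800 ng.h/mL.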

Compound 4, area under the concentration-time curve: 588 ng.h/mL
For compound 4 the middle estimate is 1.4-fold (0.13 log units) above the measured one, within the range that was stated.
By their numbers in this assay, from the lowest: compounds 3, 1, 4 and 2 (each within the scatter of the next, the first and the last beyond it).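

In this assay, placing (4-methylpiperazin-1-yl)methyl in place of (morpholin-4-yl)carbonyl on a saturated chain carbon, two bonds along the chain from an amine nitrogen, gives a step that cannot be told from no change (a 1.3-fold higher number from compound 3 to compound 4 (0.12 log units; within the scatter)). The 4-methylpiperazin-1-yl ring also stays within the scatter of both the piperidin-1-yl ring (a 1.9-fold lower number from compound 2 to compound 4 (0.28 log units; within the scatter)) and the pyridin-4-yl ring (a 1.0-fold higher number from compound 1 to compound 4 (0.02 log units; within the scatter)), so compound 4 cannot be placed with either compound 2 or compound 3, although those two lie beyond the scatter of each other. Nothing measured here accounts for these numbers.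

In every step to compound 3 the ring and the carbonyl change together, and a 3-(morpholin-4-yl)propyl chain on the amine nitrogen would part the two. Open too, going by these compounds, is how an unsubstituted piperazine or a longer chain would read at this position.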